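This account rests on a few compounds, and the source may have more. Where it says the series, first, only, none or still open, it means among the compounds named here.

Measured in a functional assay on CCRF-CEM cells (Homo sapiens) for cytotoxicity, with a stated time of 72 h; a lower number here means a stronger inhibitor, a higher number a weaker inhibitor:
- compound 1 `CCOC(=O)/C=C/C=C/C=C/C=C/c1ccc[nH]1`: 1340 nM
- compound 2 `O=C(/C=C/C=C/C=C/c1ccc[nH]1)c1ccccc1`: 3070 nM

Of these two, compound 2 has the higher number, 3070 nM, so it is the weaker inhibitor, and its gap to compound 1 lies beyond the usual scatter. Compound 3 `O=C(/C=C/C=C/C=C/C=C/c1ccc[nH]1)c1ccccc1` is still unmeasured. It departs from compound 2 by one change: 2-(1H-pyrrol-2-yl)ethenyl in place of 1H-pyrrol-2-yl on a double-bonded chain carbon bound to a double-bonded chain carbon. In words, 2-(1H-pyrrol-2-yl)ethenyl stands in place of 1H-pyrrol-2-yl on a double-bonded chain carbon bound to a double-bonded chain carbon.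

Within the data shown here, no measured pair isolates this change, so the expectation rests on thin evidence. Compound 1, which also carries 2-(1H-pyrrol-2-yl)ethenyl, gives 1340 nM, though it also differs from compound 3 elsewhere. A modest move toward a lower number in this assay is therefore expected. The estimated step is a 2.0-fold lower number from compound 2 to compound 3 (0.31 log units; beyond the scatter). Compound 3 is estimated at 1500 nM, with an expected range of 500 nM to 4000 nM.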

Compound 3, half-maximal inhibitory concentration: 720 nM
For compound 3 the middle estimate is 2.1-fold (0.32 log units) above the measured one, within the range that was stated.
By their numbers in this assay, from the lowest: compounds 3 and 1 (each within the scatter of the next); then compound 2.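

In this assay, among these compounds, 2-(1H-pyrrol-2-yl)ethenyl in place of 1H-pyrrol-2-yl on a double-bonded chain carbon bound to a double-bonded chain carbon gives a 4.3-fold lower number from compound 2 to compound 3 (0.63 log units; beyond the scatter) and so provides the first isolated reading of this change. Phenyl in place of ethoxy on a carbonyl carbon gives a 1.9-fold lower number from compound 1 to compound 3 (0.27 log units; within the scatter) and stays within the usual scatter, so the two groups are not told apart on the chain of compound 3. Nothing at hand explains either step.

This single pair does not show whether a longer chain carrying one more double bond would continue the step seen with compound 3. The series also leaves open how an amine or a carboxylic acid in place of phenyl on the carbonyl carbon would read.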